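Swapping the Bicyclic Amine for a Trimethylpiperazine

A few compounds are considered here, and "the series" means these few. Any claim that something is new, unique, unknown or untested is made for them only; others in the source may bear on it.

Measured so far:
compound 1 `Cc1cnc(CN(C)C[C@H]2Cc3c(cccc3N3CCNCC3)CN2)c(C)c1`: 21.4 nM
compound 2 `CN(C[C@H]1Cc2c(cccc2N2C[C@@H]3C[C@H]2CN3)CN1)[C@H]1CCCc2cccnc21`: 146 nM
compound 3 `CN(C[C@H]1Cc2c(cccc2N2CCN(c3cccc(C(F)(F)F)c3)CC2)CN1)[C@H]1CCCc2cccnc21`: > 16700 nM

In a functional assay on CCRF-CEM cells for antagonist activity at C-X-C chemokine receptor type 4 (Homo sapiens), read by calcium flux, with stated times of 25 min and 90 s (on this read-out lower numbers stand for stronger inhibition and higher numbers for weaker inhibition), compound 1 gives 21.4 nM and compound 2 gives 146 nM. Compound 3 reaches only a limit of this assay, > 16700 nM. Of the two numbers, compound 2 is the higher, and the number of compound 1 lies lower by more than the usual scatter.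

Compound 4 `C[C@@H]1CN(c2cccc3c2C[C@H](CN(C)[C@H]2CCCc4cccnc42)NC3)C[C@H](C)N1C` is not yet measured. It differs from compound 2 at one spot: a group of 9 heavy atoms (7 carbon, 2 nitrogen; one six-membered non-aromatic ring with 2 hetero atoms) in place of a group of 7 heavy atoms (5 carbon, 2 nitrogen; 2 five-membered non-aromatic rings with 1 hetero atom each), on an aromatic carbon. For the measured compounds named here, no measured pair shows this exact change, so the expected step rests on the spread of the three compounds. A moderate rise beyond the scatter seems the most likely outcome, though a near-unchanged number cannot be excluded. Compound 4 is therefore expected to give 300 nM, within 70 nM to 1500 nM, a step of a 2.1-fold higher number from compound 2 to compound 4 (0.31 log units; beyond the scatter) that is expected rather than known.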

Compound 4, half-maximal inhibitory concentration: 14.1 nM
Compound 4: middle estimate off by 21-fold (1.33 log units), on the high side; measured number outside the range, below it.
By their numbers in this assay, from the lowest: compounds 4 and 1 (each within the scatter of the next); then compound 2. At a limit, above all of these: compound 3.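

The group on this aromatic carbon has a large effect on the number in this assay: the 3,4,5-trimethylpiperazin-1-yl group gives a 10-fold lower number from compound 2 to compound 4 (1.02 log units; beyond the scatter). This group has no hydrogen-bond donor, so a donor here is not required for a low number. Compound 3, with another group at this position, reaches only a limit, > 16700 nM.

Nothing shown here explains the size of the step. As far as these compounds go, it remains open which methyl groups matter, and how a morpholine or a piperazine with a single methyl group would compare on this core.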